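The source may report more compounds than this note shows. Statements on the series, on what has been measured and on what is new or still open speak of the compounds shown alone.

Three compounds have been measured so far in a functional assay on HEK293 cells for agonist activity at Free fatty acid receptor 1 (Homo sapiens), read by fluorescence and calcium flux, with a stated time of 10 min; a lower number here means a smaller maximal response, a higher number a larger maximal response:

- compound 1, `O=C(O)CCc1ccc(OCC2COc3ccc(Cl)cc3O2)cc1F`: 50%
- compound 2, `O=C(O)CC(c1ccncc1)c1ccc(OCC2COc3ccc(Cl)cc3O2)cc1`: 62%
- compound 3, `CC#C[C@@H](CC(=O)O)c1ccc(OC[C@H]2COc3ccc(Cl)cc3O2)cc1`: 86%

Compound 3 stands highest of these three maximal responses. The nearest of the others is compound 2, whose value lies beyond the usual scatter below that of compound 3, and the furthest is compound 1, whose value lies still further below, again beyond the scatter. Compounds 1 and 2 carry different groups on the chain that bears the acid, so neither pair of measured compounds differs in only one place, and no single-change step can be read off from them.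

Compound 4, `CC#C[C@H](CC(=O)O)c1ccc(OC[C@@H]2COc3ccc(Cl)cc3O2)cc1`, is the next compound to be tested. The difference from compound 3 is the two compounds have the same atoms and bonds and differ only in configuration as drawn: 2 of 2 stereo elements differ (all stereocentres are inverted: mirror images); a stereocentre at a saturated chain carbon is drawn S in compound 3 and R in compound 4; a stereocentre at a saturated ring carbon is drawn S in compound 3 and R in compound 4

In the absence of any measured step of this kind, the expectation rests on the general observation that mirror-image pairs frequently show different responses in the same assay, with one form carrying most of the activity. Compound 4 is therefore expected to give a lower maximal response in this assay than compound 3, by a step likely larger than the scatter, though the size is uncertain. The estimated step is a number 41 percentage points lower from compound 3 to compound 4 (beyond the scatter). For compound 4 the expected value in this assay is 45%, within a range from 15% to 80%.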

Compound 4, largest response reached (Emax), in percent of the reference or control that the assay uses: 41%
For compound 4 the middle estimate is 4 percentage points above the measured one; the range from low to high includes it.
By their numbers in this assay, from the lowest: compounds 4 and 1 (each within the scatter of the next); then compound 2; then compound 3.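

Within the data shown here, compound 3 and compound 4 form the first pair here that can be compared directly, and inverting both stereocentres gives a number 45 percentage points lower from compound 3 to compound 4 (beyond the scatter) in this assay. This step can be assigned to configuration alone, because nothing else separates the two structures: the fact that compounds 3 and 4 differ only in the configuration as drawn. The earlier compounds shown here could not show this, since compound 1 and compound 2 are drawn without defined stereocentres and differ from each other in more than one place, whereas this pair shows that the maximal response depends strongly on three-dimensional arrangement even when every atom and bond stays the same.

Both stereocentres change together in this pair, so the compounds shown leave open how much of the step belongs to the saturated chain carbon and how much to the saturated ring carbon, a question that a form with only one of the two inverted could settle. They also leave open whether a similar gap between mirror images would appear with a different acidic group, such as a tetrazole in place of the carboxylic acid.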